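Cytotoxicity limit in a dichloro amide series

This account rests on a few compounds, and the source may have more. Where it says the series, first, only, none or still open, it means among the compounds named here.

Compound 3, whose structure is `CN1CCN(CC(=O)Nc2ccc(-c3nc4cc(Cl)c(Cl)cc4[nH]3)cc2)CC1`, is one of three compounds tested in an ADME assay on Vero cells (Chlorocebus sabaeus) for cytotoxicity; a higher number here means that more compound is tolerated, a lower number that less compound is tolerated. In this assay compound 3 reaches only the limit of > 100000 nM, not a number. Compound 1, with structure `CCC(=O)Nc1ccc(-c2nc3cc(C(F)(F)F)ccc3n2C2CCCCC2)cc1`, sits at the same limit. In this assay compound 1 gives > 100000 nM, again only a limit. Compound 2, `Oc1ccc(-c2nc3cc(C(F)(F)F)ccc3[nH]2)cc1`, is the third member. In this assay compound 2 gives > 100000 nM, once more a limit. For the measured compounds named here, the common observation is the limit of > 100000 nM in this assay, at which 3 of the 3 values shown sit, so no measured step between two numbers exists and no compound can be set apart from another.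

Compound 4, `O=C(CN1CCCCC1)Nc1ccc(-c2nc3cc(Cl)c(Cl)cc3[nH]2)cc1`, has not been measured. It differs from compound 3 by piperidin-1-yl in place of 4-methylpiperazin-1-yl on a saturated chain carbon bound to a carbonyl carbon. Going by the values given here, because every compound so far sits at the limit of > 100000 nM in this assay, at which 3 of the 3 values shown sit, the expected step from compound 3 to compound 4 is a step that the limit leaves unreadable from compound 3 to compound 4, that is, none beyond the scatter. Compound 4 is therefore expected to give an estimated 120000 nM in this assay, between 40000 nM and 400000 nM, most likely again reported only as the same limit.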

Compound 4, half-maximal cytotoxic concentration: > 100000 nM
Compound 4 gave a limit, no number (the forecaster's own chance of this, stated with the estimate: 80%); the middle value lies beyond the limit too.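

For the compounds shown here, compound 3 and compound 4 both give only limits in this assay, so no step between them can be read: the limit of > 100000 nM in this assay, at which 4 of the 4 values shown sit.

The compounds shown leave open at what concentration any of them becomes cytotoxic, and whether piperidin-1-yl and 4-methylpiperazin-1-yl differ at all.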